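The compounds below may be only part of what the source reports. "The series", "measured", "known", "first", "only" and "open" are said of these compounds alone.

Working notes on the series. The shared core is that of compound 2, `CCn1c(C(=O)NCCCO)ccc1C(CC)(CC)c1ccc(OCS(=O)(=O)c2ccccc2)c(C)c1`; the substituent on the amide-type nitrogen is what varies. Going by the values given here, in a functional assay on PC-3 cells (Homo sapiens) for antiproliferative activity, read by MTT assay, with a stated time of 24 h (on this read-out lower numbers stand for stronger inhibition and higher numbers for weaker inhibition), compound 2 gives 11300 nM, the only plain number among the values shown. Compound 1, `CCn1c(C(=O)NCCNC(=O)OC(C)(C)C)ccc1C(CC)(CC)c1ccc(OCS(=O)(=O)c2ccccc2)c(C)c1`, returns in this assay only a limit of > 50000 nM (the limit of > 50000 nM in this assay, at which 1 of the 2 values shown sits). Among the compounds with values here, the single measured step, an at least 4.4-fold lower number from compound 1 to compound 2 (0.64 log units; beyond the scatter), concerns a different change from the one now in question and so does not bear directly on it. Compound 3, `CCn1c(C(=O)N[C@H](C)C(=O)O)ccc1C(CC)(CC)c1ccc(OCS(=O)(=O)c2ccccc2)c(C)c1`, differs from compound 2 in 1-carboxyethyl in place of 3-hydroxypropyl on an amide-type nitrogen. Within the data shown here, nothing among the measured values points to a direction for this change, so the expected step, a 1.1-fold higher number from compound 2 to compound 3 (0.03 log units; within the scatter), stays within the usual scatter. The estimate for compound 3 in this assay is 12000 nM, with a range from 4000 nM to 40000 nM, and a limit rather than a number remains possible in this weak region.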

Compound 3, half-maximal inhibitory concentration: 20100 nM
The estimate for compound 3 lay 1.7-fold (0.22 log units) below the measured number; the range from low to high includes it.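

In this assay, 1-carboxyethyl in place of 3-hydroxypropyl on the amide-type nitrogen gives a 1.8-fold higher number from compound 2 to compound 3 (0.25 log units; within the scatter), so this exchange at this position cannot be told apart from the usual scatter, and the two groups leave the series in the same weak region. Measured against the 2-((tert-butoxycarbonyl)amino)ethyl group, the new group gives an at least 2.4-fold lower number from compound 1 to compound 3 (0.39 log units; beyond the scatter), the second replacement of that group to show a step beyond the scatter. This step rests on a limit and not on a number for compound 1: the limit of > 50000 nM in this assay, at which 1 of the 3 values shown sits.

Going by these compounds, whether a free amine, as in 2-aminoethyl, or a longer chain ending in a carboxylic acid would move the number out of this weak region stays open. On these data alone, the opposite configuration at the stereocentre of 1-carboxyethyl also stays open, and the true size of any step from compound 1 cannot be fixed.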